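Moving a methoxyphenyl group back onto the fused core

The source may report more compounds than this note shows. Statements on the series, on what has been measured and on what is new or still open speak of the compounds shown alone.

Of the compounds shown here, three have been tested in a functional assay on HeLa cells (Homo sapiens) for inhibition, read by cell counting, with a stated time of 4 days; on this read-out lower numbers stand for stronger inhibition and higher numbers for weaker inhibition. Compound 1 `C=C(Br)C(=O)Nc1cccc(-c2cn3nc(-c4ccccc4)sc3n2)c1` gives 1400 nM, compound 2 `C=C(Br)C(=O)Nc1cccc(-c2cn3nc(-c4cccc(OC)c4)sc3n2)c1` gives 1100 nM, and compound 3 `C=C(Br)C(=O)Nc1cccc(-c2cn3nc(CCc4ccccc4)sc3n2)c1` gives 3300 nM. Compound 3 thus stands at the highest number of the three, which on this read-out means the weakest inhibition. Adding a methoxy group gave a 1.3-fold lower number from compound 1 to compound 2 (0.10 log units; within the scatter), whereas replacing phenyl with phenethyl gave a 2.4-fold higher number from compound 1 to compound 3 (0.37 log units; beyond the scatter) and replacing 3-methoxyphenyl with phenethyl gave a 3.0-fold higher number from compound 2 to compound 3 (0.48 log units; beyond the scatter).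

Compound 4 `C=C(Br)C(=O)Nc1cccc(-c2cn3nc(-c4ccc(OC)cc4)sc3n2)c1` is not yet measured. It differs from compound 3 in one place: 4-methoxyphenyl in place of phenethyl on an aromatic carbon. This change undoes the move to phenethyl, and the steps from compound 1 and compound 2 to compound 3 both showed that the two-carbon chain raised the number modestly. The methoxy group on its own changed little in this assay. A modest step back down is therefore expected, as a 2.8-fold lower number from compound 3 to compound 4 (0.44 log units; beyond the scatter). Compound 4 is estimated at 1200 nM, within a range from 600 nM to 2500 nM.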

Compound 4, half-maximal inhibitory concentration: 2300 nM
Estimate against measurement, compound 4: 1.9-fold (0.28 log units) below; the measured number falls inside the stated range.
By their numbers in this assay, from the lowest: compounds 2, 1, 4 and 3 (each within the scatter of the next, the first and the last beyond it).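

Replacing phenethyl with 4-methoxyphenyl at this position gives a 1.4-fold lower number from compound 3 to compound 4 (0.16 log units; within the scatter), so these two groups cannot be told apart here, although phenethyl stood clearly apart from phenyl and from 3-methoxyphenyl. Going from 3-methoxyphenyl to 4-methoxyphenyl gives a 2.1-fold higher number from compound 2 to compound 4 (0.32 log units; beyond the scatter), the first sign that the placement of the methoxy on the phenyl ring can matter, even though adding it to the plain phenyl in this placement gives only a 1.6-fold higher number from compound 1 to compound 4 (0.22 log units; within the scatter). No measurement available here accounts for this difference between the two placements.

Still open, as far as these compounds go, is whether this sensitivity belongs to methoxy alone or also extends to other groups on the phenyl ring, such as a hydroxyl or an amine. It is also unclear how a benzyl group at this position would compare with phenyl and phenethyl.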